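The source may report more compounds than this note shows. Statements on the series, on what has been measured and on what is new or still open speak of the compounds shown alone.

Compound 1 `CN(C[C@H]1Cc2c(cccc2N2CCN(C3COC3)CC2)CN1)[C@H]1CCCc2cccnc21` and compound 2 `CN(C[C@H]1Cc2c(cccc2N2CCNCC2)CN1)[C@H]1CCCc2cccnc21` share one core and differ only at an amine nitrogen in a ring, which bears oxetan-3-yl in compound 1 and hydrogen in compound 2. In a functional assay on CCRF-CEM cells for agonist activity at C-X-C chemokine receptor type 4 (Homo sapiens), read by calcium flux, with a stated time of 25 min (a higher number here means that more compound is needed for the effect, a lower number that less compound is needed), compound 1 reaches only a limit of the assay, > 30000 nM. In this assay compound 2 likewise reaches only a limit, > 30000 nM. The step that the two limits leave unreadable from compound 1 to compound 2 cannot be read because both values sit at the limit (the limit of > 30000 nM in this assay, at which 2 of the 2 values shown sit). Compound 2 thus stands at a limit alone, with no measured neighbour to rank it against.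

Compound 3 `CN(C[C@H]1Cc2c(cccc2N2CCN(c3ccccn3)CC2)CN1)[C@H]1CCCc2cccnc21` has not been measured yet. It differs from compound 2 by pyridin-2-yl in place of hydrogen on an amine nitrogen in a ring. Going by the values given here, the only measured step at the same position is a step that the two limits leave unreadable from compound 1 to compound 2, and its size is not readable, so nothing here points to either direction in this assay.

For compound 3 the expected value in this assay is around 30000 nM, between 10000 nM and 100000 nM, most likely again only a limit. The step of a number no higher from compound 2 to compound 3 (the limit leaves the size open) is therefore expected to show nothing beyond the scatter.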

Compound 3, half-maximal effective concentration: > 30000 nM
Compound 3: only a limit was reported (the forecaster's own chance of this, stated with the estimate: 80%); the middle value lies on the limit itself.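

In this assay compound 3 gives only a limit, > 30000 nM. Going by these compounds alone, no step among compound 1, compound 2 and compound 3 can be read, because all three values sit at the same limit: the limit of > 30000 nM in this assay, at which 3 of the 3 values shown sit. The compounds shown leave open whether any group on this amine nitrogen can give a measurable value in this assay.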